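A few compounds are considered here, and "the series" means these few. Any claim that something is new, unique, unknown or untested is made for them only; others in the source may bear on it.

In a functional assay for inhibition, with Homo sapiens as the target (on this read-out lower numbers stand for stronger inhibition and higher numbers for weaker inhibition), compound 1 `N#Cc1cc(-c2ccoc2)c2ccc(OCc3cccc(C4(O)CCOCC4)c3)cc2c1` gives 2 nM and compound 2 `CC1(C)COC(c2cc(-c3ccoc3)c3ccc(OCc4cccc(C5(O)CCOCC5)c4)cc3c2)=N1` gives 17 nM, so compound 2 holds the higher, weaker number of the two. Compound 3 `OC1(c2cccc(COc3ccc4c(-c5ccoc5)cc(-c5nc6ccccc6s5)cc4c3)c2)CCOCC1` differs from compound 2 at one place: a group of 9 heavy atoms (7 carbon, 1 nitrogen, 1 sulfur; one five-membered aromatic ring with 2 hetero atoms, one six-membered aromatic ring of carbon only) in place of a group of 7 heavy atoms (5 carbon, 1 nitrogen, 1 oxygen; one five-membered non-aromatic ring with 2 hetero atoms), on an aromatic carbon. Within the data shown here, the one measured step at this place, an 8.5-fold higher number from compound 1 to compound 2 (0.93 log units; beyond the scatter), came when a larger group replaced a nitrile, so a modest further rise rather than a fall is expected in this assay, although a single step is thin evidence. The expected step is a 2.1-fold higher number from compound 2 to compound 3 (0.31 log units; beyond the scatter). Compound 3 is estimated at 35 nM, with an expected range of 7 nM to 170 nM.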

Compound 3, half-maximal inhibitory concentration: > 62 nM
Compound 3: no number, only a limit; the forecaster's own chance of this, stated with the estimate: 3%; at least 1.7-fold (0.24 log units) between middle value and limit.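

Compound 3 gives only a limit in this assay, not a number: the limit of > 62 nM in this assay, at which 1 of the 3 values shown sits.

Even so, the position tolerates this second change poorly, with an at least 3.6-fold higher number from compound 2 to compound 3 (0.56 log units; beyond the scatter), and swapping the nitrile directly for 1,3-benzothiazol-2-yl gives an at least 31-fold higher number from compound 1 to compound 3 (1.49 log units; beyond the scatter). Both larger groups now read weaker than the nitrile of compound 1, which is the only group shown that reaches the low end of these numbers.

From the compounds shown here alone, how an amine, a carboxylic acid or a plain methyl would read at this position stays open. The compounds shown also cannot separate the sulfur of 1,3-benzothiazol-2-yl from its fused six-membered ring.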